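Series notes: removing the dimethylcarbamoyl from compound 1

The source may report more compounds than this note shows. Statements on the series, on what has been measured and on what is new or still open speak of the compounds shown alone.

Compound 1 `CN(C)C(=O)c1cc(-c2cnc(NCc3c(F)ccc4c3CCO4)c3cn[nH]c(=O)c23)n(C)n1` was measured in a physicochemical assay for solubility, read by LC-MS, in phosphate buffer, with a stated time of 24 h, at pH 7.4 (a lower number here means a less soluble compound, a higher number a more soluble compound), and gives 3000 nM, the lowest of the two numbers in hand. Compound 2 `Cc1ncccc1-c1cnc(NCc2c(F)ccc3c2CCO3)c2nn(CC#N)c(=O)n12` gives 4000 nM in this assay, which sits within the scatter of compound 1. Compound 3 `Cn1nccc1-c1cnc(NCc2c(F)ccc3c2CCO3)c2cn[nH]c(=O)c12` is not yet measured; it differs from compound 1 by hydrogen in place of dimethylcarbamoyl on an aromatic carbon. Within the data shown here, no measured pair shows this kind of step in this assay, so the expected size is uncertain; a small decrease, possibly no larger than the scatter, is expected as a 1.5-fold lower number from compound 1 to compound 3 (0.18 log units; within the scatter). For compound 3 the estimate in this assay is 2000 nM, within 700 nM to 6000 nM.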

Compound 3, solubility: 2000 nM
For compound 3 middle estimate and measured number coincide at the digits printed, and the stated range covers the measured number.
By their numbers in this assay, from the lowest: compounds 3, 1 and 2 (each within the scatter of the next).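

In this assay, the change at this aromatic carbon of the five-membered aromatic ring reads as a 1.5-fold lower number from compound 1 to compound 3 (0.18 log units; within the scatter), the first step available for this position. The dimethylcarbamoyl can therefore be exchanged for hydrogen here with the two numbers remaining within the scatter of each other. Nothing on hand offers an explanation for this result.

Open, as far as these compounds go, is how a carboxylic acid or a primary amine at the same aromatic carbon would read against compound 3. One step also leaves open whether a longer amide chain there would read the same.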